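The source may hold more compounds than are shown below. What is called first, only, known or untested is meant among the compounds shown, and "the series" means these compounds.

Measured so far in a functional assay on A2780 cells (Homo sapiens) for antiproliferative activity, read by MTT assay, with a stated time of 72 h; a higher number here means a weaker inhibitor, a lower number a stronger inhibitor:
compound 1 `CCN(C)C(=N)NC(=N)Nc1ccc(C(F)(F)F)cc1`: 5100 nM
compound 2 `CCCCCCCNC(=N)NC(=N)Nc1ccc(F)c(F)c1`: 1500 nM
compound 3 `CC(C)CNC(=N)NC(=N)Nc1ccc(F)cc1F`: 19800 nM

Among these three, compound 2 gives the lowest number in this assay and is therefore the strongest inhibitor of the set; its gap to compound 1 and its wider gap to compound 3 both lie beyond the usual scatter of the measurement. Compound 4 `N=C(NC(=N)NC1CCCC1)Nc1ccc(F)c(F)c1` has not yet been measured. It keeps the same aryl portion as compound 2 and differs from it in one place only: cyclopentyl in place of heptyl on an amine nitrogen.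

For the measured compounds named here, no pair of measured compounds differs in exactly this way, so the size of the step cannot be read from a measured pair. What can be said is that the two compounds carrying smaller groups on that nitrogen, compound 1 and compound 3, both give higher numbers than compound 2, though each also carries a different aryl substitution, so this is at best a loose hint. On that basis compound 4 is expected to give a somewhat higher number than compound 2, with the step of a 2.7-fold higher number from compound 2 to compound 4 (0.43 log units; beyond the scatter) estimated as modest but likely beyond the scatter. The estimate for compound 4 in this assay is 4000 nM, with a range from 1500 nM to 12000 nM.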

Compound 4, half-maximal inhibitory concentration: 9300 nM
Estimate against measurement, compound 4: 2.3-fold (0.37 log units) below; measured number inside the range.
By their numbers in this assay, from the lowest: compound 2; then compounds 1 and 4 (each within the scatter of the next); then compound 3.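

In this assay, the exchange of heptyl for cyclopentyl on the amine nitrogen gives a 6.2-fold higher number from compound 2 to compound 4 (0.79 log units; beyond the scatter) with the aryl portion unchanged, so this position affects the antiproliferative readout on its own, and here the change yields a weaker inhibitor. Compound 1 and compound 3 could not show this, since each differs from compound 2 in its aryl substitution as well as in the group on that nitrogen. No measurement shown here explains the step.

The change replaces an open chain with a ring and also alters the carbon count, so the compounds shown do not separate these two differences; an unbranched pentyl chain or a cycloheptyl ring on the same nitrogen, with the same aryl portion, would bear on that question. On these data alone, it also remains open whether the same exchange gives a step of similar size alongside the trifluoromethyl substitution of compound 1 or the fluorine pattern of compound 3, and whether a chain longer than heptyl, such as octyl or decyl, would lower the number further.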